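The source may report more compounds than this note shows. Statements on the series, on what has been measured and on what is new or still open speak of the compounds shown alone.

Compound 2 `CC(C)OC(=O)N1CCC(Oc2ncnc3c2CCN3c2ccc(S(C)(=O)=O)nc2)CC1` gives the higher of the two numbers measured in a functional assay on CHO-K1 cells for agonist activity at Glucose-dependent insulinotropic receptor (Homo sapiens), read by a luciferase reporter, with a stated time of 5 h; on this read-out lower numbers stand for an effect already at smaller amounts and higher numbers for an effect only at larger amounts of compound: compound 2 gives 251 nM, while compound 1 `CCCCOC(=O)N1CCC(Oc2ncnc3c2CCN3c2ccc(S(C)(=O)=O)cc2F)CC1`, which differs from it in several places, gives 50.1 nM. The gap between these two values lies beyond the usual scatter of such measurements, so compound 2 is the weaker of the pair in this assay.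

Compound 3 `CSc1ccc(N2CCc3c(OC4CCN(C(=O)OC(C)C)CC4)ncnc32)cc1F` differs from compound 2 in a single place: a group of 9 heavy atoms (7 carbon, 1 fluorine, 1 sulfur; one six-membered aromatic ring of carbon only) in place of a group of 10 heavy atoms (6 carbon, 1 nitrogen, 2 oxygen, 1 sulfur; one six-membered aromatic ring with 1 hetero atom), on a nitrogen on an aromatic ring in a ring. Among the measured compounds shown here, no measured pair shows the effect of this exact change, so the expectation rests only on the two values above. Since compound 1, which also carries a carbon-only aromatic ring with fluorine here, gives 50.1 nM, a move toward lower numbers seems somewhat more likely than not, though the change also removes the two oxygens on sulfur. For compound 3 the expected value in this assay is 150 nM, with a range of 40 nM to 600 nM, which would be an expected step of a 1.7-fold lower number from compound 2 to compound 3 (0.22 log units; within the scatter).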

Compound 3, half-maximal effective concentration: 398 nM
Estimate against measurement, compound 3: 2.7-fold (0.42 log units) below; the range from low to high includes it.
By their numbers in this assay, from the lowest: compound 1; then compounds 2 and 3 (each within the scatter of the next).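

In this assay the exchange of groups at this position, on a nitrogen on an aromatic ring in a ring, gives a 1.6-fold higher number from compound 2 to compound 3 (0.20 log units; within the scatter) and so does not separate the two compounds. Here 6-(methylsulfonyl)pyridin-3-yl gives way to a carbon-only aromatic ring carrying fluorine and sulfur, a group with fewer hydrogen-bond acceptors and no oxygen, yet the number stays within the scatter. No measurement on hand offers an explanation for this result.

Because the ring nitrogen, the oxygens on sulfur and the fluorine all change together, this pair cannot show what each contributes alone, or whether their contributions offset one another. Also open, on these data alone, is how a group such as a nitrile or an amine would fare in place of the sulfur-bearing group on this aromatic ring.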